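This account rests on a few compounds, and the source may have more. Where it says the series, first, only, none or still open, it means among the compounds named here.

Measured compounds:
compound 1 `CCOC(=O)C1=CCCCC1S(=O)(=O)Cc1ccccc1` — 101 nM
compound 2 `CCOC(=O)C1=CCCCC1S(=O)(=O)Cc1ccc(Cl)cc1` — 101 nM

In a functional assay on RAW264.7 cells (Mus musculus), read by fluorescence (on this read-out lower numbers stand for stronger inhibition and higher numbers for weaker inhibition), compound 1 gives 101 nM and compound 2 gives 101 nM. Compound 2 thus stands level with compound 1 at the digits shown; the single measured step in this assay, no change at the digits printed from compound 1 to compound 2 (within the scatter), lies within the scatter.

Compound 3 `CCOC(=O)C1=CCCCC1S(=O)(=O)Cc1ccncc1` differs from compound 2 by pyridin-4-yl in place of 4-chlorophenyl on a saturated chain carbon bound to a sulfonyl sulfur. Within the data shown here, of the measured steps only the one from compound 1 to compound 2 bears on this change, and only loosely: it alters a substituent on the same aromatic ring, whereas here a ring carbon gives way to a ring nitrogen, a kind of change for which nothing has been measured. Given that the ring tolerated the chloro-for-hydrogen step without effect, no step beyond the scatter is expected for compound 3 in this assay, the uncertainty being widened to allow for the untested change; the expected step is a 1.5-fold higher number from compound 2 to compound 3 (0.17 log units; within the scatter). For compound 3 the estimate is 150 nM, between 40 nM and 600 nM.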

Compound 3, half-maximal inhibitory concentration: 1410 nM
Compound 3: middle estimate off by 9.4-fold (0.97 log units), on the low side, and the stated range ends below it.
By their numbers in this assay, from the lowest: compounds 1 and 2 (each within the scatter of the next); then compound 3.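

In this assay, the place on a saturated chain carbon bound to a sulfonyl sulfur proves sensitive to the identity of the aromatic ring: pyridin-4-yl in place of 4-chlorophenyl gives a 14-fold higher number from compound 2 to compound 3 (1.14 log units; beyond the scatter) and pyridin-4-yl in place of phenyl gives a 14-fold higher number from compound 1 to compound 3 (1.14 log units; beyond the scatter) in the same direction. The chloro-for-hydrogen step had shown only that this one substituent change leaves the number unmoved, so that result does not extend to replacing the carbon-only ring with a ring holding a hetero atom. Nothing available accounts for the loss.

Still open, going by these compounds, is whether the loss is tied to the ring nitrogen's place, which pyridin-3-yl and pyridin-2-yl would test. Also open, on these data alone, is how a substituent on the carbon-only ring that carries nitrogen, such as 4-aminophenyl, would read here.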